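Amino in place of 2-methoxyethoxy on compound 2

The compounds below may be only part of what the source reports. "The series", "measured", "known", "first", "only" and "open" are said of these compounds alone.

In a functional assay on HT-29 cells (Homo sapiens) for inhibition (on this read-out higher numbers stand for weaker inhibition and lower numbers for stronger inhibition), compound 1 (`COCCOc1cc(/C=C/c2ccc3ccccc3c2)ccc1OC`) gives only a limit, > 5000 nM, not a number. Compound 2 (`COCCOc1cc(/C=C\c2ccc3ccccc3c2)ccc1OC`) gives 2990 nM and compound 3 (`CN(C)c1ccc(/C=C\c2ccc3ccccc3c2)cc1`) gives 3660 nM, two values within the scatter of each other. For the measured compounds named here, the one measured step, an at least 1.6-fold lower number from compound 1 to compound 2 (0.22 log units; that floor lies within the scatter), changes only the configuration of the double bond, so it says nothing about swapping a group. Compound 4 (`COc1ccc(/C=C\c2ccc3ccccc3c2)cc1N`) has amino in place of 2-methoxyethoxy on an aromatic carbon, ortho to a methoxy group: amino in place of 2-methoxyethoxy on an aromatic carbon. Going by the values given here, no measured step makes this change. Compound 3 at 3660 nM carries different groups yet stays within the scatter of compound 2, so only a small shift is expected. The expected size is a 1.5-fold lower number from compound 2 to compound 4 (0.17 log units; within the scatter), estimated to stay within the scatter. Compound 4 is estimated at 2000 nM, with a range from 300 nM to 5000 nM in this assay.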

Compound 4, half-maximal inhibitory concentration: 1820 nM
The estimate for compound 4 lay 1.1-fold (0.04 log units) above the measured number, and the stated range covers the measured number.
By their numbers in this assay, from the lowest: compounds 4, 2 and 3 (each within the scatter of the next). At a limit, above all of these: compound 1.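

At this place, on an aromatic carbon ortho to a methoxy group, amino in place of 2-methoxyethoxy gives a 1.6-fold lower number from compound 2 to compound 4 (0.22 log units; within the scatter) in this assay. For the compounds shown here, this is the first measured step that changes the group here, as the only earlier step changed just the configuration of the double bond. Going from a chain of 5 heavy atoms to a group of 1 heavy atom thus leaves the read-out within the scatter. From the compounds shown here alone, whether a carboxylic acid or a longer chain at this place would move the number beyond the scatter stays open. Nothing shown explains why these two groups read alike.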